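The compounds below may be only part of what the source reports. "The series", "measured", "known", "first", "only" and "open" are said of these compounds alone.

Among the compounds with values here, in a physicochemical assay for solubility, at pH 7.4 (on this read-out higher numbers stand for higher solubility and lower numbers for lower solubility), compound 1 (`CC[C@H]1[C@@H](N)CN1c1c(F)cc2c(=O)c(C(=O)O)cn(C3CC3)c2c1F`) gives 55.9 ug/mL, the higher of the two numbers so far. Compound 2 (`C[C@H]1[C@H](N)CN1c1cc2c(cc1F)c(=O)c(C(=O)O)cn2C1CC1`) gives 9.9 ug/mL, a gap beyond the scatter. Within the data shown here, no single-change step between measured compounds is available as a guide. Compound 3 (`CNC1CN(c2c(F)cc3c(=O)c(C(=O)O)cn(C4CC4)c3c2F)C1`) differs from compound 1 by a group of 6 heavy atoms (4 carbon, 2 nitrogen; one four-membered non-aromatic ring with 1 hetero atom) in place of a group of 7 heavy atoms (5 carbon, 2 nitrogen; one four-membered non-aromatic ring with 1 hetero atom), on an aromatic carbon. The entering group is 3-(methylamino)azetidin-1-yl, ortho to two fluoro groups. A small downward step a 1.4-fold lower number from compound 1 to compound 3 (0.15 log units; within the scatter) is expected, not beyond the scatter. For compound 3 the estimated value is 40 ug/mL, with an expected range of 12 ug/mL to 130 ug/mL.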

Compound 3, solubility: 1.7 ug/mL
Estimate against measurement, compound 3: 24-fold (1.37 log units) above; measured number outside the range, below it.
By their numbers in this assay, from the lowest: compound 3; then compound 2; then compound 1.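

The exchange for 3-(methylamino)azetidin-1-yl on this aromatic carbon, ortho to two fluoro groups, gives a 33-fold lower number from compound 1 to compound 3 (1.52 log units; beyond the scatter) in this assay with the rest of the core unchanged. The position therefore does not tolerate every four-membered ring group alike, even though both groups have the same hydrogen-bond donor and acceptor counts and no net charge. No measurement at hand accounts for the step.

From the compounds shown here alone, it remains open whether a 3-aminoazetidin-1-yl group here would read closer to compound 1 or compound 3. Going by these compounds, it also remains open whether the same exchange would have a similar effect on the core of compound 2.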